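Chloro for Vinyl on an Aryl Sulfonamide

The source may report more compounds than this note shows. Statements on the series, on what has been measured and on what is new or still open speak of the compounds shown alone.

Two sulfonamides have been tested in an assay on isolated protein for inhibition of malate dehydrogenase, mitochondrial (Sus scrofa), with stated times of 45 min and 30 min (a higher number here means a weaker inhibitor, a lower number a stronger inhibitor), so far. Compound 1 `O=S(=O)(Nc1ccc(-c2nc3ccccc3o2)cc1)c1ccc(Cl)c(C(F)(F)F)c1` and compound 2 `C=Cc1ccc(S(=O)(=O)Nc2ccc3oc(-c4ccccc4)nc3c2)cc1` share the same core but join their pieces differently, and compound 2 carries a vinylphenyl group on its sulfonamide. In this assay compound 1 gives > 63000 nM, which is a limit of the assay rather than a number. In this assay compound 2 likewise gives > 63000 nM, again a limit and not a measured number. Among the compounds with values here, compound 2 thus stands where the only other value stands as well, and the limit of > 63000 nM in this assay, at which 2 of the 2 values shown sit, describes that place. Compound 3 `O=S(=O)(Nc1ccc2oc(-c3ccccc3)nc2c1)c1ccc(Cl)cc1` keeps the core of compound 2 and differs in one place: chloro in place of vinyl on an aromatic carbon. Within the data shown here, no step between measured compounds is available, so any expectation for this exchange rests on the two limits alone. In this assay the expected step is a step that the limit leaves unreadable from compound 2 to compound 3, which is nothing beyond the usual scatter. For compound 3 in this assay the estimate is 100000 nM, within 30000 nM to 400000 nM, and most likely the assay will again report only a limit.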

Compound 3, half-maximal inhibitory concentration: > 63000 nM
Compound 3: only a limit was reported; the forecaster's own chance of this, stated with the estimate: 85%; the middle value does not contradict the limit.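

In this assay compound 3 gives > 63000 nM which is a limit and not a number. Within the data shown here, compound 2 also stands at a limit, so no step from compound 2 to compound 3 can be read. The compounds shown leave open how strongly any of them inhibits the enzyme, and whether going from 4-vinylphenyl to 4-chlorophenyl changes that at all: the limit of > 63000 nM in this assay, at which 3 of the 3 values shown sit.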